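The source may report more compounds than this note shows. Statements on the series, on what has been measured and on what is new or still open speak of the compounds shown alone.

Compound 1 `Clc1ccc(/N=N/N2CCCC2)cc1`: > 100000 nM
Compound 2 `CN(Cc1ccccc1)/N=N/c1ccccc1`: >= 100000 nM

Both numbers come from an ADME assay on Vero cells (Chlorocebus sabaeus) for cytotoxicity, read by crystal violet staining; a lower number here means that less compound is tolerated, a higher number that more compound is tolerated. For compound 1 the value > 100000 nM is a limit of the assay, not a number. For compound 2 the value >= 100000 nM is likewise a limit of the assay. Compound 2 thus stands at the limit of >= 100000 nM in this assay, at which 1 of the 2 values shown sits, while compound 1 stands at the limit of > 100000 nM in this assay, at which 1 of the 2 values shown sits.

Compound 3 `c1ccc(CN/N=N/c2ccccc2)cc1` is not yet measured. Compared with compound 2 it carries hydrogen in place of methyl on an amine nitrogen. For the measured compounds named here, no step between measured compounds is available, so no direction can be read from them. The step is expected to be none beyond the scatter, a number no higher from compound 2 to compound 3 (the limit leaves the size open). Compound 3 is therefore estimated at 100000 nM, between 50000 nM and 200000 nM, and is likely to be reported again only as a limit.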

Compound 3, half-maximal cytotoxic concentration: 100000 nM
Compound 3: the middle estimate sits on the measured number at the digits printed; the range from low to high includes it.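

In this assay compound 3 gives 100000 nM, a number rather than a limit, which neither earlier compound provided. Compound 2 stands at >= 100000 nM, which is a limit of the assay. Hydrogen in place of methyl on this amine nitrogen therefore amounts to a number no higher from compound 2 to compound 3 (the limit leaves the size open), so the change can be bounded in direction only.

From the compounds shown here alone, whether a longer chain or a carboxylic acid in the same place would leave the number unchanged stays open. Going by these compounds, the true value of compound 2 also stays open.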